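Dichloroacetanilides: from methoxy toward trifluoromethoxy

The source may hold more compounds than are shown below. What is called first, only, known or untested is meant among the compounds shown, and "the series" means these compounds.

Compound 1 `Cc1cccc(NC(=O)C(Cl)Cl)c1`: "not determined" (no result reported) in a functional assay on Bel-7402 cells (Homo sapiens) for antiproliferative activity, read by MTT assay, with a stated time of 72 h; on this read-out lower numbers stand for stronger inhibition and higher numbers for weaker inhibition
Compound 2 `O=C(Nc1cccc(I)c1)C(Cl)Cl`: 5390 nM
Compound 3 `COc1cccc(NC(=O)C(Cl)Cl)c1`: 54800 nM

Three anilides of dichloroacetic acid share one core and differ only in the group on the aromatic ring. In this assay compound 2 gives 5390 nM, and compound 3 gives 54800 nM, the higher of the two numbers; compound 1 has no result. Within the data shown here, the one step available, a 10-fold higher number from compound 2 to compound 3 (1.01 log units; beyond the scatter), is large and beyond the scatter. Compound 4 `O=C(Nc1cccc(OC(F)(F)F)c1)C(Cl)Cl` differs from compound 3 by trifluoromethyl in place of methyl on an oxygen on an aromatic ring. Among the measured compounds shown here, no measured step reports this exact exchange; the only step at this aromatic carbon is the one just given, and it shows that what sits on that carbon can move the number strongly. The step from compound 3 to compound 4 is therefore expected to be a 4.6-fold lower number from compound 3 to compound 4 (0.66 log units; beyond the scatter), toward a lower number, because a 10-fold higher number from compound 2 to compound 3 (1.01 log units; beyond the scatter) placed the methoxy compound at the weak end. The estimate for compound 4 is 12000 nM, with a range from 3000 nM to 45000 nM.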

Compound 4, half-maximal inhibitory concentration: 10300 nM
The estimate for compound 4 lay 1.2-fold (0.07 log units) above the measured number, within the range that was stated.
By their numbers in this assay, from the lowest: compounds 2 and 4 (each within the scatter of the next); then compound 3.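

In this assay trifluoromethyl in place of methyl on the oxygen gives a 5.3-fold lower number from compound 3 to compound 4 (0.73 log units; beyond the scatter) and so shows that a change in the outer part of the group alone can move the number, with the oxygen on the aromatic ring left in place. Iodo and trifluoromethoxy on this aromatic carbon cannot be told apart (see a 1.9-fold higher number from compound 2 to compound 4 (0.28 log units; within the scatter)), while methoxy stands apart from both. Nothing shown explains either step.

The compounds shown leave open whether an amine, a carboxylic acid or a longer chain such as ethoxy on this aromatic carbon would group with compound 2 and compound 4 or with compound 3. Going by these compounds, compound 1 has no result, so its steps to the other compounds cannot be read, and the standing of methyl on this carbon stays unknown.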